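The compounds below may be only part of what the source reports. "The series", "measured", "known", "first", "only" and "open" are said of these compounds alone.

Within the data shown here, only two compounds sharing one core have numbers so far in a functional assay on FM3A cells (Mus musculus) for cytotoxicity; a higher number here means that more compound is needed for the effect, a lower number that less compound is needed. Compound 1 `CCCOOC1(OOCCC)CCCCCCCCCCC1` gives 12000 nM, and compound 2 `C=C(C)COOC1(OOC)CCCCCCCCCCC1` gives 17000 nM. Among the measured compounds shown here, these two values lie within the usual scatter of each other, so compound 2 stands level with the only other compound measured. Compound 3 `COOC1(OOCCCCCCO)CCCCCCCCCCC1` has not yet been measured in this assay. It departs from compound 2 in one place, on a saturated chain carbon bound to an oxygen on an unsaturated carbon: 5-hydroxypentyl in place of 1-methylethenyl on a saturated chain carbon bound to an oxygen on an unsaturated carbon. Cut one bond further out, the same change reads 2-methylprop-2-en-1-yl to 6-hydroxyhexyl. For the measured compounds named here, no measured pair shows what this change does, and neither measured compound carries the 5-hydroxypentyl group, so the expectation is loose. It rests on compound 2 at 17000 nM, and no step beyond the scatter is expected in this assay. The estimated step of a 1.1-fold lower number from compound 2 to compound 3 (0.05 log units; within the scatter) is therefore small, with no firm direction. Compound 3 is expected at 15000 nM, with an estimated range of 5000 nM to 40000 nM.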

Compound 3, half-maximal effective concentration: 1600 nM
Compound 3: the middle estimate sits 9.4-fold (0.97 log units) above what was measured; the measured number lies below the stated range.
By their numbers in this assay, from the lowest: compound 3; then compounds 1 and 2 (each within the scatter of the next).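

In this assay, 5-hydroxypentyl in place of 1-methylethenyl on a saturated chain carbon bound to an oxygen on an unsaturated carbon gives an 11-fold lower number from compound 2 to compound 3 (1.03 log units; beyond the scatter), the only step beyond the scatter among the compounds shown. Among these compounds, this position can therefore move the number substantially, which the earlier compounds, level with each other, gave no sign of. The change also replaces a group with a double bond and no hydrogen-bond donor or acceptor by a larger one that has no double bond and carries one of each, so this single step joins several differences and cannot assign the drop to any one of them. Nothing shown accounts for the size of the step.

The compounds shown leave open whether the terminal hydroxyl or the chain itself carries the effect, since a plain hexyl chain or a shorter hydroxyalkyl chain in this place would separate the two. They also leave open whether another end group on the same chain, such as an amine or a carboxylic acid, would give a similar number.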